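Notes on the carbonyl aryl change from compound 1 to compound 4

A few compounds are considered here, and "the series" means these few. Any claim that something is new, unique, unknown or untested is made for them only; others in the source may bear on it.

compound 1 `COc1cc(-c2cc(/C=C/C(=O)c3ccc(Cl)c(Cl)c3)[nH]n2)cc(OC)c1OC`: > 100000 nM in a functional assay on COLO 205 cells (Homo sapiens) for inhibition, read by sulforhodamine B assay, with a stated time of 48 h (a higher number here means that more compound is tolerated, a lower number that less compound is tolerated), a limit of the assay, not a number
compound 2 `COc1ccc(-c2cc(/C=C/C(=O)c3ccc(N)cc3)[nH]n2)cc1OC`: 6870 nM in this assay
compound 3 `COc1ccc(-c2cc(/C=C/C(=O)c3ccc(N)cc3)[nH]n2)cc1`: 6410 nM in this assay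

Compound 1 stands at the assay limit (the limit of > 100000 nM in this assay, at which 1 of the 3 values shown sits). Compound 4 `COc1ccc(C(=O)/C=C/c2cc(-c3cc(OC)c(OC)c(OC)c3)n[nH]2)cc1OC` differs from it by 3,4-dimethoxyphenyl in place of 3,4-dichlorophenyl on a carbonyl carbon. For the measured compounds named here, the only measured step, a 1.1-fold lower number from compound 2 to compound 3 (0.03 log units; within the scatter), changes a different ring and gives no guidance on the carbonyl aryl; compound 2 and compound 3 carry 4-aminophenyl there, and no compound shows 3,4-dimethoxyphenyl or 3,4-dichlorophenyl against another group on that carbon. The direction of the change is therefore open. Compound 4 is expected at 30000 nM, between 6000 nM and 150000 nM, which would mean an at least 3.3-fold lower number from compound 1 to compound 4 (0.52 log units; beyond the scatter); a further limit is a real possibility.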

Compound 4, concentration lethal to 50% of the cells: 5920 nM
Estimate against measurement, compound 4: 5.1-fold (0.70 log units) above; measured number outside the range, below it.
By their numbers in this assay, from the lowest: compounds 4, 3 and 2 (each within the scatter of the next). At a limit, above all of these: compound 1.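

On a carbonyl carbon, 3,4-dimethoxyphenyl in place of 3,4-dichlorophenyl gives an at least 16-fold lower number from compound 1 to compound 4 (1.22 log units; beyond the scatter) in this assay. For the compounds shown here, this is the first direct reading at this position, and it shows that the carbonyl aryl alone can move the core of compound 1 from the limit to a measured value. The step has only a lower bound, as compound 1 is a limit: the limit of > 100000 nM in this assay, at which 1 of the 4 values shown sits.

Open, on these data alone, is whether the methoxy groups or the absence of chlorine accounts for the step. Plain phenyl or 3,4-dihydroxyphenyl on that carbon would separate the two.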